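The source may hold more compounds than are shown below. What is called first, only, known or untested is meant among the compounds shown, and "the series" means these compounds.

Measured compounds:
- compound 1, `O=C(O)C[C@@H]1CCCN1c1ccc(Oc2ccc(Cl)cc2Cl)cc1`, 360 nM
- compound 2, `O=C(O)C[C@@H]1CCCN1c1ccc(Oc2ccccc2F)cc1`, 150 nM
- compound 3, `CC(C)(C)c1ccccc1Oc1ccc(N2CCC[C@H]2CC(=O)O)cc1`, 6500 nM

All three share one core and differ only in the aromatic ring carried on the ether oxygen. In a functional assay on cells for agonist activity at Free fatty acid receptor 1 (Homo sapiens), read by FLIPR and calcium flux, with a stated time of 100 s (a higher number here means that more compound is needed for the effect, a lower number that less compound is needed), compound 2 gives the lowest number of the three; compound 1 stands nearest with a 2.4-fold lower number from compound 1 to compound 2 (0.38 log units; beyond the scatter), and compound 3 stands furthest with a 43-fold higher number from compound 2 to compound 3 (1.64 log units; beyond the scatter).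

Compound 4, `COc1ccc(Oc2ccc(N3CCC[C@H]3CC(=O)O)cc2)cc1`, is not yet measured. It differs from compound 2 in one place: 4-methoxyphenyl in place of 2-fluorophenyl on an oxygen on an aromatic ring.

For the measured compounds named here, two measured steps bear on this change. The step from compound 1 to compound 2 shows that exchanging one substituted phenyl for another on this oxygen moves the number only modestly. The step from compound 2 to compound 3 shows that a tert-butyl on that ring, where the fluoro of compound 2 sits, costs a great deal. Compound 4 neither keeps the fluoro nor carries a tert-butyl; its methoxy stands elsewhere on the ring and brings one hydrogen-bond acceptor. Nothing measured tells how that is received. Compound 4 is therefore expected to sit somewhat above compound 2, a step of about a 2.7-fold higher number from compound 2 to compound 4 (0.43 log units; beyond the scatter), well short of what compound 3 showed. The estimate for compound 4 in this assay is 400 nM, with a range from 120 nM to 1500 nM.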

Compound 4, half-maximal effective concentration: 520 nM
Estimate against measurement, compound 4: 1.3-fold (0.11 log units) below; low and high end bracket the measured number.
By their numbers in this assay, from the lowest: compound 2; then compounds 1 and 4 (each within the scatter of the next); then compound 3.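

In this assay, the step to the 4-methoxyphenyl group is a 3.5-fold higher number from compound 2 to compound 4 (0.54 log units; beyond the scatter), so losing the 2-fluorophenyl group costs something real but remains modest, even though the entering group brings a hydrogen-bond acceptor that the leaving group lacks. Set against the 2,4-dichlorophenyl group, the same 4-methoxyphenyl group gives a 1.4-fold higher number from compound 1 to compound 4 (0.16 log units; within the scatter), so this assay does not separate these two differently substituted rings, and the 2-fluorophenyl group of compound 2 alone stands apart from both at the low end of the series. Nothing available explains why the 2-fluorophenyl group gives the lowest number or why the other two rings cannot be told apart, and the data show only the size of these steps, not their origin.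

The compounds shown leave open whether the gain seen with compound 2 belongs to the fluoro itself or to the place it occupies on the ring, a question that a 4-fluorophenyl group or an unsubstituted phenyl group would address. They also leave open how a 2-methoxyphenyl group, or a longer chain such as ethoxy in place of the methoxy, would be received on this oxygen.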